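A few compounds are considered here, and "the series" means these few. Any claim that something is new, unique, unknown or untested is made for them only; others in the source may bear on it.

Measured compounds:
- compound 1, `O=C(Nc1ccccc1C(F)(F)F)C1CCc2ccccc2N1`: 45500 nM
- compound 2, `O=C(Nc1ccccc1C(F)(F)F)C1CCc2ccccc2N1C(=O)c1cccc(Cl)c1`: 288 nM
- compound 3, `O=C(Nc1ccccc1O)C1CCc2ccccc2N1`: 5260 nM

Of the compounds shown here, three have been measured in a functional assay on MDA-MB-231 cells (Homo sapiens) for cytotoxicity, read by sulforhodamine B assay, with a stated time of 72 h; on this read-out higher numbers stand for weaker inhibition of growth and lower numbers for stronger inhibition of growth. Compound 1 `O=C(Nc1ccccc1C(F)(F)F)C1CCc2ccccc2N1` gives 45500 nM in this assay. Compound 2 `O=C(Nc1ccccc1C(F)(F)F)C1CCc2ccccc2N1C(=O)c1cccc(Cl)c1` differs from compound 1 by the change ((3-chlorophenyl)carbonyl in place of hydrogen on a nitrogen on an aromatic ring in a ring), and this gives a 160-fold lower number from compound 1 to compound 2 (2.20 log units; beyond the scatter). Compound 3 `O=C(Nc1ccccc1O)C1CCc2ccccc2N1` differs from compound 1 by the change (hydroxy in place of trifluoromethyl on an aromatic carbon), and this gives an 8.7-fold lower number from compound 1 to compound 3 (0.94 log units; beyond the scatter).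

Compound 4 `O=C(Nc1ccccc1O)C1CCc2ccccc2N1C(=O)c1cccc(Cl)c1` has not yet been measured in this assay. It differs from compound 3 by (3-chlorophenyl)carbonyl in place of hydrogen on a nitrogen on an aromatic ring in a ring, the same change as from compound 1 to compound 2, made here on the core of compound 3 rather than of compound 1; the two cores differ by hydroxy in place of trifluoromethyl on an aromatic carbon. Whether the change is as large on the second core cannot be known from the data, since it has been made only once.

Compound 4 is expected to show an 88-fold lower number from compound 3 to compound 4 (1.94 log units; beyond the scatter), a somewhat smaller step than the earlier one, because the large step of a 160-fold lower number from compound 1 to compound 2 (2.20 log units; beyond the scatter) was seen on a different core and such a step is not certain to carry over unchanged. The estimate for compound 4 is 60 nM, with a likely range from 15 nM to 300 nM.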

Compound 4, concentration for 50% growth inhibition: 10600 nM
Compound 4: middle estimate off by 180-fold (2.25 log units), on the low side, and the stated range ends below it.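

On the core of compound 3, (3-chlorophenyl)carbonyl in place of hydrogen gives a 2.0-fold higher number from compound 3 to compound 4 (0.30 log units; within the scatter) in this assay, so the large step seen on the core of compound 1 did not carry over: the same change on two cores in this assay, a 160-fold lower number (2.20 log units; beyond the scatter) from compound 1 to compound 2 and a 2.0-fold higher number (0.30 log units; within the scatter) from compound 3 to compound 4, 320-fold (2.50 log units) apart, beyond the scatter of two such steps

Hydroxy in place of trifluoromethyl likewise depends on the core, giving a 37-fold higher number from compound 2 to compound 4 (1.57 log units; beyond the scatter) once the (3-chlorophenyl)carbonyl group is present, and so this step does not match the one seen without that group: the same change on two cores in this assay, an 8.7-fold lower number (0.94 log units; beyond the scatter) from compound 1 to compound 3 and a 37-fold higher number (1.57 log units; beyond the scatter) from compound 2 to compound 4, 320-fold (2.50 log units) apart, beyond the scatter of two such steps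

The two changes therefore do not add up independently in this series, but four compounds on two pairs of cores do not show why, nor how either change would behave on any further core.

From the compounds shown here alone, whether a methoxy, a chlorine or an amine on that aromatic carbon would behave like trifluoromethyl or like hydroxy remains open. So does whether a smaller acyl group on that nitrogen, such as acetyl, would follow the pattern of (3-chlorophenyl)carbonyl on either core.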